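The compounds below may be only part of what the source reports. "The series", "measured", "known", "first", "only" and "open" are said of these compounds alone.

Measured compounds:
- compound 1, `C=C1[C@@H](OC(C)=O)C[C@@H]2[C@](C)(CO[Si](C)(C)C(C)(C)C)[C@H](OC(C)=O)CC[C@@]2(C)[C@@H]1C[C@@H](Nc1ccc(OC)cc1)C1=CCOC1=O`: 5370 nM
- compound 2, `C=C1[C@@H](OC(C)=O)C[C@@H]2[C@](C)(COC=O)[C@H](OC(C)=O)CC[C@@]2(C)[C@@H]1C[C@@H](Nc1ccc(OC)c(OC)c1)C1=CCOC1=O`: 42800 nM
- compound 3, `C=C1CC[C@@H]2[C@](C)(CO[Si](C)(C)C(C)(C)C)[C@H](OC(C)=O)CC[C@@]2(C)[C@@H]1C/C=C1/C(=O)OC[C@H]1OC(C)=O`: 4690 nM

In a functional assay on HT-29 cells (Homo sapiens) for cytotoxicity, read by sulforhodamine B assay (on this read-out higher numbers stand for weaker inhibition and lower numbers for stronger inhibition), compound 2 gives the highest of the three numbers; compound 1 and compound 3 sit beyond the scatter from it and close to each other. Compound 4, `C=C1[C@@H](OC(C)=O)C[C@@H]2[C@](C)(COC=O)[C@H](OC(C)=O)CC[C@@]2(C)[C@@H]1C[C@@H](Nc1ccc(C(=O)O)cc1)C1=CCOC1=O`, has not been measured; it differs from compound 2 by 4-carboxyphenyl in place of 3,4-dimethoxyphenyl on an amine nitrogen. Among the measured compounds shown here, no measured pair in this set makes this kind of change, so there is no step to lean on. Because compound 2 already gives 42800 nM, only a shift within or modestly beyond the scatter is expected, most likely toward a higher number, so that the step of a 1.4-fold higher number from compound 2 to compound 4 (0.15 log units; within the scatter) is expected to be small. Compound 4 is estimated at 60000 nM, with a range from 15000 nM to 200000 nM.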

Compound 4, half-maximal inhibitory concentration: 37200 nM
Compound 4: the middle estimate sits 1.6-fold (0.21 log units) above what was measured; low and high end bracket the measured number.
By their numbers in this assay, from the lowest: compounds 3 and 1 (each within the scatter of the next); then compounds 4 and 2 (each within the scatter of the next).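

In this assay, among the compounds shown here, placing 4-carboxyphenyl instead of 3,4-dimethoxyphenyl on the amine nitrogen gives a 1.2-fold lower number from compound 2 to compound 4 (0.06 log units; within the scatter), the first step in this set that can be read at this position. On this core and at this high level of the read-out, the two groups cannot be told apart. Nothing given here accounts for this result.

Going by these compounds, whether a methyl ester of the acid, an unsubstituted phenyl or an aminomethyl group at this place would move the number stays open. So does whether the same exchange would read alike on the core of compound 1.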